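Diethylamino for Dimethylamino, Repeated on a Second Core

The source may report more compounds than this note shows. Statements on the series, on what has been measured and on what is new or still open speak of the compounds shown alone.

Of the compounds shown here, three have been measured in a functional assay on A549 cells (Homo sapiens) for antiproliferative activity, read by MTT assay, with a stated time of 72 h; a higher number here means a weaker inhibitor, a lower number a stronger inhibitor. Compound 1 `COc1cc2ncnc(N3CCc4ccccc43)c2cc1NC(=O)/C=C/CN(C)C` gives 2040 nM in this assay. Compound 2 `CCN(CC)C/C=C/C(=O)Nc1cc2c(N3CCc4ccccc43)ncnc2cc1OC` gives 1690 nM in this assay, and compound 3 `COc1cc2ncnc(N3CCCc4ccccc43)c2cc1NC(=O)/C=C/CN(C)C` gives 1650 nM in this assay. Compound 2 differs from compound 1 by diethylamino in place of dimethylamino on a saturated chain carbon bound to a double-bonded chain carbon, and that change made a step of a 1.2-fold lower number from compound 1 to compound 2 (0.08 log units; within the scatter). Compound 3 differs from compound 1 in its core, namely (1,2,3,4-tetrahydroquinolin-1-yl in place of 2,3-dihydro-1H-indol-1-yl on an aromatic carbon), with a step of a 1.2-fold lower number from compound 1 to compound 3 (0.09 log units; within the scatter). Compound 4 `CCN(CC)C/C=C/C(=O)Nc1cc2c(N3CCCc4ccccc43)ncnc2cc1OC` has not yet been measured in this assay; it carries the core of compound 3 and differs from compound 3 by diethylamino in place of dimethylamino on a saturated chain carbon bound to a double-bonded chain carbon. This is the same change as the one between compound 1 and compound 2, at the same place, and it occurs twice among these four compounds. Because the earlier step was a 1.2-fold lower number from compound 1 to compound 2 (0.08 log units; within the scatter), the step expected in this assay is a 1.2-fold lower number from compound 3 to compound 4 (0.07 log units; within the scatter), within the scatter. Compound 4 is accordingly estimated at 1400 nM in this assay, with a range expected from 700 nM to 2800 nM.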

Compound 4, half-maximal inhibitory concentration: 6410 nM
Compound 4: middle estimate off by 4.6-fold (0.66 log units), on the low side; measured number outside the range, above it.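

On the second core, diethylamino in place of dimethylamino gave a 3.9-fold higher number from compound 3 to compound 4 (0.59 log units; beyond the scatter) in this assay, so the step seen on the first core did not carry over: the same change on two cores in this assay, a 1.2-fold lower number (0.08 log units; within the scatter) from compound 1 to compound 2 and a 3.9-fold higher number (0.59 log units; beyond the scatter) from compound 3 to compound 4, 4.7-fold (0.67 log units) apart, beyond the scatter of two such steps

Read the other way, with diethylamino on the chain, 1,2,3,4-tetrahydroquinolin-1-yl in place of 2,3-dihydro-1H-indol-1-yl gave a 3.8-fold higher number from compound 2 to compound 4 (0.58 log units; beyond the scatter), and this step likewise parts from its counterpart with dimethylamino: the same change on two cores in this assay, a 1.2-fold lower number (0.09 log units; within the scatter) from compound 1 to compound 3 and a 3.8-fold higher number (0.58 log units; beyond the scatter) from compound 2 to compound 4, 4.7-fold (0.67 log units) apart, beyond the scatter of two such steps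

The two changes therefore do not add up independently across these four compounds, and compound 4 is the one that departs from the others; this does not show why, and a single pair on each core gives no general rule for the series.

The compounds shown leave open whether the departure belongs to diethylamino alone or would also appear on the core of compound 3 with another amine on the same chain, such as pyrrolidin-1-yl or morpholin-4-yl. They also leave open whether it would persist in cells other than those of this assay.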